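Adding a Chlorobenzyl to the Piperazine of Compound 3

This account rests on a few compounds, and the source may have more. Where it says the series, first, only, none or still open, it means among the compounds named here.

Three compounds share one core and differ only at its edge. Compound 1 `Cn1c(-c2ccc(NC(=O)CSc3nc4ccccc4o3)cc2)nc(-c2ccccc2)c1-c1ccccc1` gives 41% in a functional assay on HT-29 cells (Homo sapiens) for cytotoxicity, read by MTT assay, with a stated time of 24 h, tested at 1.6 ug/mL; on this read-out higher numbers stand for a stronger effect at the one concentration tested and lower numbers for a weaker effect. Compound 2 `Cc1ccc2oc(SCC(=O)Nc3ccc(-c4nc(-c5ccccc5)c(-c5ccccc5)n4C)cc3)nc2c1` gives 15.5% in this assay, and compound 3 `CCN1CCN(CC(=O)Nc2ccc(-c3nc(-c4ccccc4)c(-c4ccccc4)n3C)cc2)CC1` gives 13.9% in this assay. Among the three numbers compound 3 stands at the bottom of the list, but its distance to compound 2 is within the scatter, so those two cannot be told apart; only the step of a number 27.1 percentage points lower from compound 1 to compound 3 (beyond the scatter) is beyond the scatter. The step of a number 25.5 percentage points lower from compound 1 to compound 2 (beyond the scatter) shows how far a methyl on an aromatic carbon lowered the number, while the step of a number 1.6 percentage points lower from compound 2 to compound 3 (within the scatter) is within the scatter.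

Compound 4 `Cn1c(-c2ccc(NC(=O)CN3CCN(Cc4ccc(Cl)cc4)CC3)cc2)nc(-c2ccccc2)c1-c1ccccc1` differs from compound 3 in one place: 4-chlorophenyl in place of methyl on a saturated chain carbon bound to an amine nitrogen in a ring. For the measured compounds named here, none of the measured steps touches this part of the molecule: they concern the methyl on the aromatic carbon or the exchange of (1,3-benzoxazol-2-yl)sulfanyl for 4-ethylpiperazin-1-yl. There is therefore no direct guide, and the step of a number 4.1 percentage points higher from compound 3 to compound 4 (within the scatter) is expected not to go beyond the scatter, with a wide range around it. Compound 4 is estimated at 18%, between 6% and 38%.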

Compound 4, a percentage reported as activity, at one concentration (the size of the read-out at that concentration, not a potency): 16.4%
For compound 4 the middle estimate is 1.6 percentage points above the measured one; low and high end bracket the measured number.
By their numbers in this assay, from the lowest: compounds 3, 2 and 4 (each within the scatter of the next); then compound 1.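

In this assay, exchanging the ethyl of compound 3 for the 4-chlorobenzyl of compound 4 gives a number 2.5 percentage points higher from compound 3 to compound 4 (within the scatter), so the two compounds cannot be told apart. For the compounds shown here, this is the first view of this position, on a saturated chain carbon bound to an amine nitrogen in a ring, and it shows that one carbon can give way to a 4-chlorophenyl, with its six-membered aromatic ring and chlorine, without the read-out at this single concentration moving beyond the usual scatter. No measurement shown here gives any information on why the larger group and the smaller one read alike.

With only these two groups at this position, the contributions of the aromatic ring and the chlorine cannot be separated, and a plain benzyl would be the direct test of what the chlorine adds. As far as these compounds go, it also remains open whether a carboxylic acid, a primary amine or a longer chain ending in a phenyl ring at the same place would give a number beyond the scatter of compound 3.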